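A few compounds are considered here, and "the series" means these few. Any claim that something is new, unique, unknown or untested is made for them only; others in the source may bear on it.

Three compounds have been measured in an ADME assay on WI-38 cells (Homo sapiens) for cytotoxicity, read by MTT assay, with a stated time of 72 h; on this read-out lower numbers stand for stronger inhibition and higher numbers for weaker inhibition:
compound 1 `CN(C)CCn1cnnc1-c1cc(Oc2ccc(NC(=O)N/N=C/c3ccc(F)cc3Cl)cc2F)ccn1` gives 2090 nM;
compound 2 `CN(C)CCn1cnnc1-c1cc(Oc2ccc(NC(=O)N/N=C/c3c(O)ccc4ccccc34)cc2F)ccn1` gives 3250 nM;
compound 3 `CN(C)CCn1cnnc1-c1cc(Oc2ccc(NC(=O)N/N=C/c3ccc(F)cc3)cc2F)ccn1` gives 3980 nM.

Compound 3 sits at the upper end of these three numbers, yet its steps to both neighbours stay within the scatter: a 1.9-fold higher number from compound 1 to compound 3 (0.28 log units; within the scatter) and a 1.2-fold higher number from compound 2 to compound 3 (0.09 log units; within the scatter). Compound 4 `COc1cc(/C=N/NC(=O)Nc2ccc(Oc3ccnc(-c4nncn4CCN(C)C)c3)c(F)c2)ccc1O` is not yet measured; it differs from compound 3 by 4-hydroxy-3-methoxyphenyl in place of 4-fluorophenyl on a carbon with a double bond to nitrogen. For the measured compounds named here, the steps that bear on this exchange of the aryl group, a 1.6-fold higher number from compound 1 to compound 2 (0.19 log units; within the scatter) and a 1.2-fold higher number from compound 2 to compound 3 (0.09 log units; within the scatter), are both within the scatter, so no step beyond the scatter is expected in this assay, in either direction. Compound 4 is therefore estimated at 4000 nM, within 2000 nM to 8000 nM, which would mean a 1.0-fold higher number from compound 3 to compound 4 (0.00 log units; within the scatter).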

Compound 4, half-maximal inhibitory concentration: 5320 nM
Compound 4: middle estimate off by 1.3-fold (0.12 log units), on the low side; the measured number falls inside the stated range.
By their numbers in this assay, from the lowest: compounds 1, 2, 3 and 4 (each within the scatter of the next, the first and the last beyond it).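

In this assay the exchange of 4-fluorophenyl for 4-hydroxy-3-methoxyphenyl on a carbon with a double bond to nitrogen stays within the scatter (a 1.3-fold higher number from compound 3 to compound 4 (0.13 log units; within the scatter)), as does the exchange of 2-hydroxynaphthalen-1-yl for the same group (a 1.6-fold higher number from compound 2 to compound 4 (0.21 log units; within the scatter)). New here is the first step at this position beyond the scatter, though only a modest one (a 2.5-fold higher number from compound 1 to compound 4 (0.41 log units; beyond the scatter)). No measurement given here accounts for these numbers. Still open, as far as these compounds go, is whether an amine or a carboxylic acid on this aryl ring, or a longer chain in its place, would give a larger step.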